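Fluoro to methyl: expected clearance of compound 3

The source may hold more compounds than are shown below. What is called first, only, known or untested is meant among the compounds shown, and "the series" means these compounds.

Values so far in an ADME assay on the whole organism for pharmacokinetics, with Rattus norvegicus as the target, at a dose of 1 mg/kg by the intravenous route (on this read-out higher numbers stand for fast clearance and lower numbers for slow clearance), are these:
compound 1 `Cc1cc(C(=O)O)cc(C)c1NC(=O)c1cc(-c2cccc(CO)c2)ccc1F` gives 91 mL/min/kg
compound 2 `Cc1ccc(-c2cccc(CO)c2)cc1C(=O)Nc1c(C)ccc(C(=O)O)c1C` gives 15 mL/min/kg

Compound 1 stands highest of the two, and compound 2 lies lower by a margin beyond the scatter. Compound 3 `Cc1ccc(-c2cccc(CO)c2)cc1C(=O)Nc1c(C)cc(C(=O)O)cc1C` follows from compound 1 by one change methyl in place of fluoro on an aromatic carbon with methyl in place of fluoro on an aromatic carbon, ortho to a large group and para to a 3-(hydroxymethyl)phenyl group. Going by the values given here, no pair of measured compounds shows this change alone, so its size in this assay remains unknown. The only lower figure available is compound 2 at 15 mL/min/kg and it points cautiously downward. A fall somewhat beyond the scatter is expected for the step of a 2.6-fold lower number from compound 1 to compound 3 (0.41 log units; beyond the scatter) in this direction. For compound 3 the estimated clearance is 35 mL/min/kg with a range from 13 mL/min/kg to 90 mL/min/kg before measurement.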

Compound 3, clearance in the Rattus norvegicus assay: 71 mL/min/kg
For compound 3 the middle estimate is 2.0-fold (0.31 log units) below the measured one; measured number inside the range.
By their numbers in the Rattus norvegicus assay, from the lowest: compound 2; then compounds 3 and 1 (each within the scatter of the next).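

Read directly for the first time, methyl in place of fluoro on this aromatic carbon, ortho to a large group and para to a 3-(hydroxymethyl)phenyl group, gives in the Rattus norvegicus assay a 1.3-fold lower number from compound 1 to compound 3 (0.11 log units; within the scatter), so on this single pair the change leaves clearance within the scatter. Compound 2 therefore gave no guide to the size of this step. The same change is far from silent in a physicochemical assay for solubility, read by HPLC, with a stated time of 20 h, at pH 6 (a higher number here means a more soluble compound, a lower number a less soluble compound), where compound 1 gives 774 ug/mL and compound 3 gives 31 ug/mL, and the two compounds part widely: the measured solubility of compound 1, 774 ug/mL, and of compound 3, 31 ug/mL, a 25-fold lower number (1.40 log units; beyond the scatter).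

Going by these compounds, this rests on one pair on one core, so it remains open whether a chloro or a methoxy group on the same carbon would stay level with compound 1 in the Rattus norvegicus assay, and where such a group would fall in the physicochemical assay. What sets compound 2 at 15 mL/min/kg in the Rattus norvegicus assay apart also cannot be read from a single step.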